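This account rests on a few compounds, and the source may have more. Where it says the series, first, only, none or still open, it means among the compounds named here.

Compound 1 `CCCC[N+](C)(C)CCCC(=O)[O-]` carries a butyl group on its quaternary amine nitrogen. In an assay for inhibition of gamma-butyrobetaine dioxygenase (Homo sapiens), read by HPLC, with stated times of 15 min and 30 min (on this read-out higher numbers stand for weaker inhibition and lower numbers for stronger inhibition), compound 1 reaches only a limit of the assay, > 1000000 nM. That is the limit of > 1000000 nM in this assay, at which 1 of the 2 values shown sits. Compound 2 `CC(C)[N+](C)(C)CCCC(=O)[O-]` gives 5700 nM in this assay, and the step of an at least 170-fold lower number from compound 1 to compound 2 (2.24 log units; beyond the scatter) shows that isopropyl in place of butyl on the amine nitrogen goes with far stronger inhibition. Compound 3 `C[N+](C)(CCl)CCCC(=O)[O-]` makes a related change at the same nitrogen: chloro in place of propyl on a saturated chain carbon bound to an amine nitrogen. A large step in the same direction is expected, an at least 50-fold lower number from compound 1 to compound 3 (1.69 log units; beyond the scatter), because an at least 170-fold lower number from compound 1 to compound 2 (2.24 log units; beyond the scatter) was large. Compound 3 is therefore estimated at 20000 nM, with a range from 2000 nM to 500000 nM.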

Compound 3, half-maximal inhibitory concentration: 268000 nM
Beside the measured number, compound 3's estimate is 13-fold (1.13 log units) below it; low and high end bracket the measured number.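

In this assay, chloromethyl on the amine nitrogen still improves on butyl, with an at least 3.7-fold lower number from compound 1 to compound 3 (0.57 log units; beyond the scatter), though this step starts from a limit and not from a true number: the limit of > 1000000 nM in this assay, at which 1 of the 3 values shown sits.

Set against isopropyl, chloromethyl loses much of that strength, with a 47-fold higher number from compound 2 to compound 3 (1.67 log units; beyond the scatter), so replacing butyl does not by itself reach the level of compound 2. The groups on this nitrogen are therefore far from interchangeable.

On these data alone, what remains open is whether the chlorine itself counts or only the size of the group. An ethyl or fluoromethyl group on this nitrogen would help separate the two.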